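Putting 4-chlorophenyl on the ring nitrogen of compound 1

This account rests on a few compounds, and the source may have more. Where it says the series, first, only, none or still open, it means among the compounds named here.

Going by the values given here, in a functional assay on HepG2 cells (Homo sapiens) for antiproliferative activity, read by MTT assay, with a stated time of 72 h (on this read-out lower numbers stand for stronger inhibition and higher numbers for weaker inhibition), compound 1 `COc1ncc(-c2ccc3c(c2)NC(=O)CO3)cc1NS(=O)(=O)c1ccc(F)cc1` gives the lowest number so far (6590 nM). Compound 2 `O=C1COc2ccc(-c3cnc(Cl)c(NS(=O)(=O)c4ccc(F)cc4)c3)cc2N1`, with chloro in place of methoxy on an aromatic carbon, reaches only a limit (> 40000 nM). Among the compounds with values here, that step (an at least 6.0-fold higher number from compound 1 to compound 2 (0.78 log units; beyond the scatter)) is the only single-change comparison, and it concerns another part of the molecule. Compound 4 `COc1ncc(-c2ccc3c(c2)N(c2ccc(Cl)cc2)C(=O)CO3)cc1NS(=O)(=O)c1ccc(F)cc1` instead has 4-chlorophenyl in place of hydrogen on an amide-type nitrogen in a ring. Compound 3 `COc1ccc(N2C(=O)COc3ccc(-c4cccc(NS(=O)(=O)c5ccc(F)cc5)c4)cc32)cc1` also carries an aromatic ring on that nitrogen and, despite having no methoxy, still gives a number (29800 nM). Compound 4 keeps the methoxy, so a modest fall is expected (a 2.6-fold lower number from compound 1 to compound 4 (0.42 log units; beyond the scatter)), though with wide uncertainty. For compound 4 the estimated value is 2500 nM (expected range 400 nM to 15000 nM).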

Compound 4, half-maximal inhibitory concentration: 17900 nM
Compound 4: the middle estimate sits 7.2-fold (0.85 log units) below what was measured; the whole stated range lies below it.
By their numbers in this assay, from the lowest: compound 1; then compounds 4 and 3 (each within the scatter of the next). At a limit, above all of these: compound 2.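

In this assay, 4-chlorophenyl in place of hydrogen on the amide-type nitrogen in a ring weakens the effect modestly, with a 2.7-fold higher number from compound 1 to compound 4 (0.43 log units; beyond the scatter). This shows that the nitrogen position also moves the read-out, which the earlier single-change comparison, made at another part of the molecule, could not show. Only compound 2 sits at a limit rather than a number: the limit of > 40000 nM in this assay, at which 1 of the 4 values shown sits.

Going by these compounds, whether the loss comes from the aromatic ring itself or from its chlorine stays open. So does the effect of a methyl group or a short chain carrying an amine on this nitrogen.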